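A few compounds are considered here, and "the series" means these few. Any claim that something is new, unique, unknown or untested is made for them only; others in the source may bear on it.

The measured compounds in an assay on membranes from brain for displacement of a labelled ligand from adenosine receptor A1 (Rattus norvegicus); on this read-out higher numbers stand for weaker inhibition and lower numbers for stronger inhibition:
compound 1, `Brc1ccc(-c2nc3ccccn3c2NC2CCCCC2)cc1`, with 3900 nM;
compound 2, `Oc1ccc(-c2nc3ccccn3c2NC2CCCCC2)cc1`, with 5530 nM.
Compound 3, `Clc1ccc(-c2nc3ccccn3c2NC2CCCCC2)cc1`, gives in this assay no number but only the limit > 100000 nM.

Compound 3 thus stands at the weak end of the three, and because the limit of > 100000 nM in this assay, at which 1 of the 3 values shown sits, nothing more than that limit is known of it. Compound 1 and compound 2 lie within the scatter of each other, as a 1.4-fold higher number from compound 1 to compound 2 (0.15 log units; within the scatter) shows. From both of them the move to compound 3 is large: an at least 25-fold higher number from compound 1 to compound 3 (1.40 log units; beyond the scatter) and an at least 18-fold higher number from compound 2 to compound 3 (1.25 log units; beyond the scatter), each at least as big as the limit allows to say.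

Compound 4, `c1ccc(-c2nc3ccccn3c2NC2CCCCC2)cc1`, is not yet measured in this assay. It differs from compound 3 by hydrogen in place of chloro on an aromatic carbon. The two large measured steps bear on this change, since both lead into the chloro compound 3 from a compound carrying a different group at the same place. Removing the chloro altogether is expected to undo at least part of that loss, so compound 4 is estimated at 15000 nM, between 3000 nM and 100000 nM, which means an expected step of an at least 6.6-fold lower number from compound 3 to compound 4 (0.82 log units; beyond the scatter) from the limit of compound 3.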

Compound 4, inhibition constant: > 100000 nM
Compound 4: a limit, no number; the forecaster's own chance of this, stated with the estimate: 25%; middle value at least 6.6-fold (0.82 log units) away from the limit.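

Taking the chloro away from compound 3 does not bring back a measured number in this assay. Compound 4, with hydrogen in place of the chloro, also gives only a limit. The step to hydrogen is large from both compounds that have numbers, with an at least 25-fold higher number from compound 1 to compound 4 (1.40 log units; beyond the scatter) and an at least 18-fold higher number from compound 2 to compound 4 (1.25 log units; beyond the scatter), so among these four compounds a measured number goes only with bromo and hydroxy, and not with chloro or hydrogen. The step between compound 3 and compound 4 itself cannot be read, because neither of them has a number: the limit of > 100000 nM in this assay, at which 2 of the 4 values shown sit.

As far as these compounds go, what an amine, a methoxy or a fluoro group at this place, para to a large group, would give in this assay stays open, and with it whether bromo and hydroxy are exceptions or part of a wider set of groups that keep a measurable number. Also open, from the compounds shown here alone, are how far compound 3 and compound 4 lie beyond the limit, and whether the sharp split between bromo and chloro would hold with a change elsewhere on the shared core.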